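Swapping Methyl for Fluoro on a Weak Inhibitor

This account rests on a few compounds, and the source may have more. Where it says the series, first, only, none or still open, it means among the compounds named here.

Compound 1 `C=CCn1c(=O)/c(=C\c2cccc(C)c2)[nH]c(=O)/c1=C\c1ccccc1OC` is a weak inhibitor in a functional assay on Huh-7 cells (Homo sapiens) for cytotoxicity, read by CCK-8 assay, with a stated time of 72 h (a lower number here means a stronger inhibitor, a higher number a weaker inhibitor), where compound 1 gives 21400 nM. Among the compounds that have a number, compound 1 stands highest, meaning weakest. Compound 2 `COc1ccccc1/C=c1\c(=O)[nH]/c(=C/c2cccc(Cl)c2Cl)c(=O)n1C` differs from it in several places at once, and in this assay compound 2 gives 300 nM, a far lower number and so a far stronger inhibitor; that gap lies well beyond the scatter. Compound 3 `C=CCn1c(=O)/c(=C\c2ccc(Cl)c(Cl)c2)[nH]c(=O)/c1=C\c1ccccc1` was reported in this assay as "not active" (no number reported), without a number.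

For the measured compounds named here, the new compound 4 `C=CCn1c(=O)/c(=C\c2cccc(F)c2)[nH]c(=O)/c1=C\c1ccccc1OC` keeps the core of compound 1 and changes only one group: fluoro in place of methyl on an aromatic carbon. Going by the values given here, no measured pair shows this exact change, so there is no step to lean on. A swap of this small size, with no change in rings, donors or acceptors, is expected to move the number little, so the step of a 1.2-fold lower number from compound 1 to compound 4 (0.08 log units; within the scatter) is expected to stay within the scatter. Compound 4 is therefore estimated at 18000 nM, with a range from 6000 nM to 60000 nM.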

Compound 4, half-maximal inhibitory concentration: 27200 nM
Compound 4: the middle estimate sits 1.5-fold (0.18 log units) below what was measured; the measured number falls inside the stated range.
By their numbers in this assay, from the lowest: compound 2; then compounds 1 and 4 (each within the scatter of the next).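

In this assay, replacing 3-methylphenyl with 3-fluorophenyl gives a 1.3-fold higher number from compound 1 to compound 4 (0.10 log units; within the scatter) and so leaves compound 1 and compound 4 indistinguishable. For the compounds shown here, this is the first pair here that differs in one place only, and it shows that, at this spot on the ring, this read-out does not separate fluoro from methyl, with both compounds remaining weak inhibitors. No measurement at hand speaks to what lies behind this result.

Still open, from the compounds shown here alone, is whether a quite different group at the same place, such as an amine or a carboxylic acid, would move the number beyond the scatter. Also open is which single feature accounts for the far lower number of compound 2, since it differs from compound 1 and compound 4 in several places at once.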